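The source may hold more compounds than are shown below. What is called first, only, known or untested is meant among the compounds shown, and "the series" means these compounds.

Compound 1 `Cc1ccc(S(=O)(=O)Nc2ccc(-c3nc4ccccc4o3)cc2)cc1` is a sulfonamide built on a shared core. In an assay on isolated protein for inhibition of malate dehydrogenase, mitochondrial (Sus scrofa), with stated times of 45 min and 30 min (on this read-out lower numbers stand for stronger inhibition and higher numbers for weaker inhibition), compound 1 gives > 63000 nM, which is a limit of the assay rather than a measured number. Two relatives show the same outcome. Compound 2 `O=S(=O)(Nc1ccc2oc(-c3ccccc3)nc2c1)c1cccc(O)c1` gives > 63000 nM in this assay, again a limit. Compound 3 `O=S(=O)(Nc1ccc2oc(-c3ccccc3)nc2c1)c1ccccc1O` gives > 63000 nM in this assay, also a limit. Among the compounds with values here, the one step between measured compounds, a step that the two limits leave unreadable from compound 2 to compound 3, therefore cannot be read, since both ends sit at the limit. Within the data shown here, what the three values share is the limit of > 63000 nM in this assay, at which 3 of the 3 values shown sit, so no measured step shows how any change on the ring carrying the sulfonyl sulfur moves inhibition.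

Compound 4 `COc1ccc(S(=O)(=O)Nc2ccc(-c3nc4ccccc4o3)cc2)cc1` is the compound still to be measured. It differs from compound 1 in one place: methoxy in place of methyl on an aromatic carbon. Among the measured compounds shown here, no measured step involves a methoxy or a methyl on that ring, and the only available step is unreadable. The expectation for compound 4 therefore rests on compound 1 alone, whose result is a limit. The step that the limit leaves unreadable from compound 1 to compound 4 is expected to be none beyond the scatter, with compound 4 most likely also ending at the limit. Compound 4 is estimated at 100000 nM, with a range from 30000 nM to 400000 nM.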

Compound 4, half-maximal inhibitory concentration: > 63000 nM
Compound 4 ended at the assay's limit; the forecaster's own chance of this, stated with the estimate: 90%; the middle value lies beyond the limit too.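

Compound 1 and compound 4 both end at a limit rather than a measured number, so the swap of methyl for methoxy gives no step that can be read in this assay: the limit of > 63000 nM in this assay, at which 4 of the 4 values shown sit.

The compounds shown leave open whether any change to these sulfonamides gives a measurable inhibition, and which part of them would matter for it.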